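This account rests on a few compounds, and the source may have more. Where it says the series, first, only, none or still open, it means among the compounds named here.

Working notes on the series. Compound 1 `COc1ccc(Oc2ccc3c(NCCCNCc4cc(F)ccc4OC)ccnc3c2)cc1` is the point of departure. In an ADME assay for permeability, using PAMPA, with a stated time of 30 min, at pH 7.4 (on this read-out lower numbers stand for lower permeability and higher numbers for higher permeability), compound 1 gives 317 10^-6 cm/s, level with compound 2 `COc1ccc(Oc2ccc3c(NCCCNCc4cccc(OC)c4O)ccnc3c2)cc1` at 317 10^-6 cm/s; together these two stand at the top of the three numbers, while compound 3 `COc1cccc(CNCCCNc2ccnc3cc(-c4cc(C(F)(F)F)cc(C(F)(F)F)c4)ccc23)c1O` gives 237 10^-6 cm/s, a gap to compound 1 that stays within the scatter. Within the data shown here, the single measured step, no change at the digits printed from compound 1 to compound 2 (within the scatter), swaps the aryl group on the saturated chain carbon bound to the amine nitrogen, 2-hydroxy-3-methoxyphenyl in place of 5-fluoro-2-methoxyphenyl, and leaves this assay unmoved.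

Compound 4 `COc1ccc(F)cc1CNCCCNc1ccnc2cc(Oc3ccccc3OC)ccc12` differs from compound 1 elsewhere, on the oxygen on an aromatic ring whose other neighbour is aromatic carbon: 2-methoxyphenyl in place of 4-methoxyphenyl on an oxygen on an aromatic ring Cut one bond further out, the difference reads 4-methoxyphenoxy to 2-methoxyphenoxy; the two compounds hold the same atoms, joined differently. Among the measured compounds shown here, no measured step touches this oxygen-linked ring, so there is no direct precedent. What the series does show is that a change at the opposite end of compound 1 left this assay flat, and that all three numbers sit within the scatter of one another. For compound 4 the expected step is therefore a 1.1-fold lower number from compound 1 to compound 4 (0.02 log units; within the scatter), nothing beyond the scatter. Compound 4 is estimated at 300 10^-6 cm/s, between 170 10^-6 cm/s and 530 10^-6 cm/s.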

Compound 4, apparent permeability: 317 10^-6 cm/s
The estimate for compound 4 lay 1.1-fold (0.02 log units) below the measured number; the range from low to high includes it.
By their numbers in this assay, from the lowest: compounds 3, 1, 2 and 4 (each within the scatter of the next).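

Read in this assay, the step from the 4-methoxyphenyl to the 2-methoxyphenyl group on the oxygen, no change at the digits printed from compound 1 to compound 4 (within the scatter), gives this oxygen-linked ring a measured step of its own, which the earlier compounds did not provide. Compound 1 now has two measured single changes in different places, the other being no change at the digits printed from compound 1 to compound 2 (within the scatter), and neither moves this assay beyond the scatter, so the flat reading no longer rests on the aryl group on the saturated chain carbon alone. Nothing available accounts for this flat result, and the two steps give no reason for it.

The step covers only a rearrangement of the same atoms, so it leaves open whether the number would hold with a different group on this oxygen, such as 3-methoxyphenyl, a pyridine ring or a benzoic acid. Also open, as far as these compounds go, is whether a larger change, such as an amine or a carboxylic acid on the ring, or a longer chain in place of the one joining the two amine nitrogens, would take this assay beyond the scatter.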